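From Butyl to Isopropyl on the Furan Ring

The source may report more compounds than this note shows. Statements on the series, on what has been measured and on what is new or still open speak of the compounds shown alone.

For the measured compounds named here, in an assay on CHO cells for displacement of a labelled ligand from C-X-C chemokine receptor type 1 (Homo sapiens) (a lower number here means a stronger inhibitor, a higher number a weaker inhibitor), compound 2 `CCCCc1coc([C@@H](CC)Nc2c(Nc3cccc(C(=O)N(C)C)c3O)c(=O)c2=O)c1` gives 34 nM, the higher of the two numbers measured so far, while compound 1 `CC[C@@H](Nc1c(Nc2cccc(C(=O)N(C)C)c2O)c(=O)c1=O)c1cc(C)cs1` gives 24 nM, and the step of a 1.4-fold higher number from compound 1 to compound 2 (0.15 log units; within the scatter) lies within the scatter. Compound 3 `CC[C@@H](Nc1c(Nc2cccc(C(=O)N(C)C)c2O)c(=O)c1=O)c1cc(C(C)C)co1` differs from compound 2 by isopropyl in place of butyl on an aromatic carbon. Going by the values given here, no measured step alters this alkyl group; the single known step exchanges the ring instead and stays within the scatter. For compound 3 in this assay a step of a 1.0-fold higher number from compound 2 to compound 3 (0.01 log units; within the scatter) is therefore expected, none beyond the scatter. Compound 3 is estimated at 35 nM, with a range from 15 nM to 80 nM.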

Compound 3, inhibition constant: 3 nM
The estimate for compound 3 lay 12-fold (1.07 log units) above the measured number; measured number below the stated range.
By their numbers in this assay, from the lowest: compound 3; then compounds 1 and 2 (each within the scatter of the next).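

With this assay, the alkyl group on this furan carbon proves decisive: isopropyl in place of butyl brings an 11-fold lower number from compound 2 to compound 3 (1.05 log units; beyond the scatter), whereas the earlier exchange of ring and alkyl group stayed within the scatter. The 4-isopropylfuran-2-yl group also separates from 4-methylthiophen-2-yl, with an 8.0-fold lower number from compound 1 to compound 3 (0.90 log units; beyond the scatter). No available evidence accounts for this gain. From the compounds shown here alone, whether a propyl or a tert-butyl group at this carbon would match isopropyl remains open. So does whether 4-isopropylthiophen-2-yl would give a number like that of compound 3.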